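Trading the Sulfamoyl Group for an Ethoxy Group

The compounds below may be only part of what the source reports. "The series", "measured", "known", "first", "only" and "open" are said of these compounds alone.

Of the compounds shown here, three have been measured in an assay on isolated protein for inhibition of alkaline phosphatase, tissue-nonspecific isozyme (Bos taurus), read by chemiluminescence and spectrophotometry; on this read-out lower numbers stand for stronger inhibition and higher numbers for weaker inhibition. Compound 1 `NS(=O)(=O)c1cccc(NC(=O)c2ccc(F)cc2)c1` gives 55600 nM, compound 2 `Cc1ccc(S(=O)(=O)Nc2ccc(S(N)(=O)=O)cc2)cc1` gives 222000 nM, and compound 3 `NS(=O)(=O)c1ccc(NS(=O)(=O)c2ccc(F)cc2)cc1` gives 3260 nM. Compound 2 thus stands highest of the three numbers, with compound 1 its nearest neighbour and compound 3 its furthest. Among the compounds with values here, the only single-point step among them, a 68-fold lower number from compound 2 to compound 3 (1.83 log units; beyond the scatter), is large and concerns a fluoro in place of a methyl.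

Compound 4 `CCOc1ccc(NS(=O)(=O)c2ccc(C)cc2)cc1` awaits measurement. It differs from compound 2 by ethoxy in place of sulfamoyl on an aromatic carbon. Within the data shown here, no measured step touches this part of the structure: every measured compound carries the sulfamoyl group, and the step from compound 2 to compound 3 changes a different substituent. Among the measured compounds shown here, there is therefore no direct precedent, and the expectation rests on the absence of the sulfamoyl group from compound 4 alone. The account expects the number for compound 4 to move upward, by a 2.3-fold higher number from compound 2 to compound 4 (0.35 log units; beyond the scatter). Compound 4 is estimated at 500000 nM, within a range from 120000 nM to 2000000 nM, and the assay may well return only a limit for it.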

Compound 4, half-maximal inhibitory concentration: 310 nM
For compound 4 the middle estimate is 1600-fold (3.21 log units) above the measured one, outside the stated range (below it).
By their numbers in this assay, from the lowest: compound 4; then compound 3; then compound 1; then compound 2.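

In this assay, the exchange of sulfamoyl for ethoxy gives a 720-fold lower number from compound 2 to compound 4 (2.85 log units; beyond the scatter), a large step in the direction of stronger inhibition. Within the data shown here, the sulfamoyl group is therefore not required at this position, on an aromatic carbon para to a large group, for a low number in this assay, something the earlier compounds could not show because all of them carry it. Nothing available here explains the size of this step.

Still open, as far as these compounds go, is whether the step comes from the ethoxy group itself or from the loss of sulfamoyl, a question that a methoxy group, a propoxy chain or a plain hydrogen at this position would bear on. From the compounds shown here alone, it is also open whether the same exchange gives a comparable step with the fluoro group of compound 3 in place of the methyl group.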